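Removing the chloro from the hydrazone aryl ring

The compounds below may be only part of what the source reports. "The series", "measured", "known", "first", "only" and "open" are said of these compounds alone.

Measured so far:
- compound 1, `COc1ccc(OC)c(/C=C/c2nnc(Nc3ccc(Cl)cc3)o2)c1`, in a functional assay on PC-3 cells (Homo sapiens) for antiproliferative activity, read by sulforhodamine B assay, with a stated time of 48 h (a lower number here means a stronger inhibitor of growth, a higher number a weaker inhibitor of growth), compound 1 gives 76000 nM
- compound 2, `COc1ccc(OC)c(/C=C/C(=O)N/N=C/c2ccc(Cl)cc2)c1`, in this assay compound 2 gives > 100000 nM

Compound 2 stands at a limit: its value in this assay is a limit of the assay and not a number, as the limit of > 100000 nM in this assay, at which 1 of the 2 values shown sits, records. Compound 1 gives a number, and what the two values show is that neither compound is a notable inhibitor of growth in this assay.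

The next compound is compound 3, `COc1ccc(OC)c(/C=C/C(=O)N/N=C/c2ccccc2)c1`. It differs from compound 2 by hydrogen in place of chloro on an aromatic carbon. Among the compounds with values here, no measured pair here isolates this change, so the size of the step must be guessed; the expectation is no step beyond the usual scatter, in either direction. Compound 3 is expected at 120000 nM, with a range from 50000 nM to 300000 nM, and the step that the limit leaves unreadable from compound 2 to compound 3 is expected to be flat.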

Compound 3, concentration for total growth inhibition: 52100 nM
The estimate for compound 3 lay 2.3-fold (0.36 log units) above the measured number; measured number inside the range.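

In this assay, compound 3 gives a number, 52100 nM, so with hydrogen at this position on the aromatic ring the hydrazone gives a readable value. Compound 2 stands at a limit of the assay and not at a number: the limit of > 100000 nM in this assay, at which 1 of the 3 values shown sits. The change from 4-chlorophenyl to phenyl therefore reads only as a floor, an at least 1.9-fold lower number from compound 2 to compound 3 (0.28 log units; that floor lies within the scatter), which shows that the chloro is not needed for the weak growth inhibition of compound 3, while the floor alone does not separate compound 2 from compound 3.

Going by these compounds, how far the step extends past that floor stays open, and a single pair gives no trend at this position. On these data alone, whether an amine, a carboxylic acid or a bromo group here would shift the number is also open.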